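The compounds below may be only part of what the source reports. "The series", "measured", "known", "first", "only" and "open" are said of these compounds alone.

Of the compounds shown here, two have been measured so far in a functional assay on NCI-H661 cells (Homo sapiens) for antiproliferative activity, read by MTT assay, with a stated time of 72 h; a lower number here means a stronger inhibitor, a higher number a weaker inhibitor. Compound 1 `Cc1ccc(-c2noc(CCCCCCC(=O)NO)n2)cc1` gives 15800 nM in this assay. Compound 2 `COc1ccc(-c2noc(CCCCCCC(=O)NO)n2)cc1`, carrying a methoxy in place of methyl on an aromatic carbon, gives 20400 nM in this assay, and the step of a 1.3-fold higher number from compound 1 to compound 2 (0.11 log units; within the scatter). Compound 2 thus stands at the higher of the two numbers, a gap that lies within the scatter, so the two compounds cannot be told apart.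

Compound 3 `COc1ccc(-c2noc(CCCCCCC(=O)C(F)(F)F)n2)cc1` keeps the methoxy of compound 2 but alters the end of the chain: trifluoromethyl in place of hydroxyamino on a carbonyl carbon. Among the measured compounds shown here, no measured step touches this part of the structure; the only measured step concerns the aromatic ring, so it gives no guide to the size or direction of this change in this assay. The estimate for compound 3 therefore starts from compound 2 and carries a wide range. For compound 3 a step of a 1.5-fold higher number from compound 2 to compound 3 (0.17 log units; within the scatter) in this assay is expected, giving an estimated 30000 nM with a range from 8000 nM to 100000 nM.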

Compound 3, half-maximal inhibitory concentration: 5050 nM
Compound 3: middle estimate off by 5.9-fold (0.77 log units), on the high side; the measured number lies below the stated range.
By their numbers in this assay, from the lowest: compound 3; then compounds 1 and 2 (each within the scatter of the next).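

Compound 3 shows that, in this assay, the end of the chain is a place where a single change can move the number: replacing hydroxyamino with trifluoromethyl on the carbonyl carbon gives a 4.0-fold lower number from compound 2 to compound 3 (0.61 log units; beyond the scatter) and so goes beyond the scatter, which the earlier change on the aromatic ring did not. The hydroxyamino group, with its hydrogen-bond donors, is therefore not needed for activity in this pair, since the stronger compound has none at that place. No measurement shown here accounts for this difference.

From the compounds shown here alone, it remains open whether this gain is specific to trifluoromethyl or would also appear with a methyl group or a hydroxyl group, as in a carboxylic acid, on the same carbonyl carbon. Going by these compounds, it is also open whether the same change would give a similar step with methyl on the aromatic ring, or on a longer chain.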